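The source may report more compounds than this note shows. Statements on the series, on what has been measured and on what is new or still open speak of the compounds shown alone.

Compound 2 `O=c1[nH]c2ccccc2cc1/C=N/c1ccc(O)cc1` was tested in a functional assay, read by spectrophotometry, with a stated time of 1 h (a higher number here means a weaker inhibitor, a lower number a stronger inhibitor), and returned no single number, being reported only as "not active" (no number reported). Its relatives set the scale: compound 1 `Cc1ccc2[nH]c(=O)c(/C=N/c3ccccc3O)cc2c1` gives 1350000 nM in this assay, and compound 3 `Cc1ccc2[nH]c(=O)c(/C=N/Nc3ccccc3)cc2c1` gives 1470000 nM, a step of a 1.1-fold higher number from compound 1 to compound 3 (0.04 log units; within the scatter). Compound 4 `NS(=O)(=O)c1ccc(/N=C/c2cc3ccccc3[nH]c2=O)cc1` differs from compound 2 by sulfamoyl in place of hydroxy on an aromatic carbon. Within the data shown here, no measured step swaps sulfamoyl for hydroxy, so the one known step, anilino in place of 2-hydroxyphenyl, bears on it only as a sign that a swap on that nitrogen left the number within the scatter. Compound 4 is therefore expected to remain a weak inhibitor, with a real chance of again yielding no number. The estimate for compound 4 is 1500000 nM, between 500000 nM and 5000000 nM.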

Compound 4, half-maximal inhibitory concentration: 266000 nM
For compound 4 the middle estimate is 5.6-fold (0.75 log units) above the measured one; the whole stated range lies above it.
By their numbers in this assay, from the lowest: compound 4; then compounds 1 and 3 (each within the scatter of the next).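

In this assay, among these compounds, compound 2 carries no number, and so no step from it to compound 4 can be read. What sulfamoyl in place of hydroxy does to the number stays open, and no measurement shown explains the result of compound 4.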